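Swapping the Aryl Group on the Ring Nitrogen

The source may report more compounds than this note shows. Statements on the series, on what has been measured and on what is new or still open speak of the compounds shown alone.

Compound 1 `N#CC1=C(N)Oc2c(N)cc3nc4ccccc4nc3c2C12C(=O)N(Cc1cnnn1-c1ccc([N+](=O)[O-])cc1)c1ccccc12` and compound 2 `Cc1cc(C)cc(-n2nncc2CN2C(=O)C3(C(C#N)=C(N)Oc4c(N)cc5nc6ccccc6nc5c43)c3ccccc32)c1` share one core. In a functional assay on HepG2 cells (Homo sapiens) for antiproliferative activity, read by MTT assay, with a stated time of 48 h (a lower number here means a stronger inhibitor, a higher number a weaker inhibitor), compound 1 reaches only the limit of > 50000 nM. In this assay compound 2 likewise reaches only the limit of > 50000 nM. Within the data shown here, the single measured step, a step that the two limits leave unreadable from compound 1 to compound 2, cannot be sized because both values sit at the limit of > 50000 nM in this assay, at which 2 of the 2 values shown sit. Compound 3 `Cc1ccc(Cl)cc1-n1nncc1CN1C(=O)C2(C(C#N)=C(N)Oc3c(N)cc4nc5ccccc5nc4c32)c2ccccc21` differs from compound 2 by 5-chloro-2-methylphenyl in place of 3,5-dimethylphenyl on an aromatic nitrogen. No readable step bears on this change, so nothing beyond the scatter is expected. Compound 3 is expected to give 50000 nM, with a range from 20000 nM to 150000 nM, most likely again as a limit. The expected step, a number no higher from compound 2 to compound 3 (the limit leaves the size open), is estimated as flat.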

Compound 3, half-maximal inhibitory concentration: 17300 nM
Compound 3: the middle estimate sits 2.9-fold (0.46 log units) above what was measured; measured number outside the range, below it.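

Compound 3 is the only one of the three with a readable number in this assay, so the aryl group on this aromatic nitrogen can move the result after all: the limit of > 50000 nM in this assay, at which 2 of the 3 values shown sit. 5-Chloro-2-methylphenyl gives an at least 2.8-fold lower number from compound 2 to compound 3 (0.46 log units; beyond the scatter) and an at least 2.8-fold lower number from compound 1 to compound 3 (0.46 log units; beyond the scatter). The first of these changes leaves the heavy-atom, donor and acceptor counts of the group as they were.

The compounds shown do not separate the part played by the chlorine from that of the methyl arrangement. On these data alone, how an amine or a carboxylic acid on this aryl ring would read remains open.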